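Phenyl in Place of Thiophene on a Shared Nucleoside Core

A few compounds are considered here, and "the series" means these few. Any claim that something is new, unique, unknown or untested is made for them only; others in the source may bear on it.

Measured compounds:
compound 1, `O=c1[nH]cnc2c1c(-c1cccs1)cn2[C@@H]1O[C@H](CO)[C@@H](O)[C@H]1O`: in a functional assay on K562 cells (Homo sapiens), read by MTT assay, with a stated time of 72 h (on this read-out higher numbers stand for weaker inhibition and lower numbers for stronger inhibition), compound 1 gives > 20000 nM, a limit of the assay rather than a number.
compound 2, `CSc1ncnc2c1c(-c1cccs1)cn2[C@@H]1O[C@H](CO)[C@@H](O)[C@H]1O`: in this assay compound 2 gives > 20000 nM, again a limit.
compound 3, `COc1nc(N)nc2c1c(-c1ccco1)cn2[C@@H]1O[C@H](CO)[C@@H](O)[C@H]1O`: in this assay compound 3 gives > 20000 nM, also a limit.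

For the measured compounds named here, compound 1 thus stands nowhere in particular among the three: all of them sit at the limit of > 20000 nM in this assay, at which 3 of the 3 values shown sit, and no measured pair differs in a single place, so no step between measured compounds can be read. The data give no indication that any of the changes among these three moves the read-out.

Compound 4, `O=c1[nH]cnc2c1c(-c1ccccc1)cn2[C@@H]1O[C@H](CO)[C@@H](O)[C@H]1O`, differs from compound 1 by phenyl in place of thiophen-2-yl on an aromatic carbon. With every measured value resting at the limit, the expected step, a step that the limit leaves unreadable from compound 1 to compound 4, is none beyond the usual scatter. Compound 4 is accordingly estimated at 30000 nM, with a range from 10000 nM to 100000 nM, and most likely it will again be reported only as a limit.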

Compound 4, half-maximal inhibitory concentration: > 20000 nM
Compound 4: a limit, no number (the forecaster's own chance of this, stated with the estimate: 85%); the middle value is on the limit's open side.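

Compound 1 and compound 4 both rest at a limit rather than a number, so no step can be read for phenyl in place of thiophen-2-yl: the limit of > 20000 nM in this assay, at which 4 of the 4 values shown sit.

The compounds shown leave open whether any change on the shared core moves the read-out at all.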